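Lengthening a Short Side Chain on a Kinase Inhibitor

This account rests on a few compounds, and the source may have more. Where it says the series, first, only, none or still open, it means among the compounds named here.

Compound 1 `CN1C(=O)C(C2CC2)N(C)c2nc(Nc3ccc(S(N)(=O)=O)cc3)ncc21` gives 136 nM in an assay on Sf9 cells for inhibition of serine/threonine-protein kinase 4 (Homo sapiens), read by luminescence and ADP-Glo, with a stated time of 1 h, in the presence of a further agent that is not named here; on this read-out lower numbers stand for stronger inhibition and higher numbers for weaker inhibition. Compound 2 `CN1CC(=O)N(C)c2cnc(Nc3ccc(S(N)(=O)=O)cc3)nc21` gives 495 nM in this assay, and compound 3 `CCC1C(=O)N(C)c2cnc(Nc3ccc(S(N)(=O)=O)cc3)nc2N1C` gives 479 nM. Among these three numbers compound 3 holds the second highest; its number and that of compound 2 lie within the scatter of each other, whereas the step of a 3.5-fold higher number from compound 1 to compound 3 (0.55 log units; beyond the scatter) is beyond it. Compound 4 `CCCC1C(=O)N(C)c2cnc(Nc3ccc(S(N)(=O)=O)cc3)nc2N1C` differs from compound 3 by methyl in place of hydrogen on a saturated chain carbon, two bonds along the chain from a saturated ring carbon. For the measured compounds named here, two measured steps bear on this change. The step of a 1.0-fold lower number from compound 2 to compound 3 (0.01 log units; within the scatter) shows that placing an ethyl on the saturated ring carbon, where before there was hydrogen, left the number essentially where it was. Going by the values given here, the only step beyond the scatter, a 3.5-fold higher number from compound 1 to compound 3 (0.55 log units; beyond the scatter), concerns the exchange of cyclopropyl for ethyl rather than a change in chain length. Growing the ethyl to a propyl is therefore expected to give a step of no more than the scatter in this assay, in no clear direction. Compound 4 is expected to give 450 nM, with a range from 180 nM to 1200 nM. This estimate corresponds to an expected step of a 1.1-fold lower number from compound 3 to compound 4 (0.03 log units; within the scatter).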

Compound 4, half-maximal inhibitory concentration: 206 nM
Compound 4: the middle estimate sits 2.2-fold (0.34 log units) above what was measured; the measured number falls inside the stated range.
By their numbers in this assay, from the lowest: compounds 1 and 4 (each within the scatter of the next); then compounds 3 and 2 (each within the scatter of the next).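

One more carbon does register at this position: growing ethyl to propyl gives a step beyond the scatter in this assay (a 2.3-fold lower number from compound 3 to compound 4 (0.37 log units; beyond the scatter)), although ethyl in place of hydrogen gave none (a 1.0-fold lower number from compound 2 to compound 3 (0.01 log units; within the scatter)). Propyl in place of hydrogen on the saturated ring carbon also moves the number beyond the scatter (a 2.4-fold lower number from compound 2 to compound 4 (0.38 log units; beyond the scatter)), so the response to chain length across hydrogen, ethyl and propyl is not a steady one. The open propyl chain and the cyclopropyl ring cannot be told apart on this carbon in this assay (a 1.5-fold higher number from compound 1 to compound 4 (0.18 log units; within the scatter)).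

Going by these compounds, whether a longer chain such as butyl, a branched group such as isopropyl or a chain ending in an amine would lower the number further remains open. The data at hand offer no evidence on why the added carbon of propyl counts when ethyl showed no change from hydrogen.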